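A few compounds are considered here, and "the series" means these few. Any claim that something is new, unique, unknown or untested is made for them only; others in the source may bear on it.

Measured compounds:
- compound 1, `Fc1ccc(-n2cc(COc3ccccc3-c3nc4ccccc4s3)nn2)cc1Cl`, 27300 nM
- compound 2, `Fc1ccc(-n2cc(COc3ccccc3-c3nc4ccccc4s3)nn2)cc1`, 26200 nM

The read-out throughout is a functional assay on MCF7 cells (Homo sapiens) for cytotoxicity, read by MTT assay, with a stated time of 24 h; on this read-out higher numbers stand for weaker inhibition and lower numbers for stronger inhibition. Compound 1 and compound 2 sit within the scatter of each other: a 1.0-fold lower number from compound 1 to compound 2 (0.02 log units; within the scatter). Within the data shown here, compound 2 therefore stands on a number that is not separated from the only other value shown.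

Compound 3, `FC(F)(F)c1cccc(-n2cc(COc3ccccc3-c3nc4ccccc4s3)nn2)c1`, has not yet been measured. It differs from compound 2 as follows: 3-(trifluoromethyl)phenyl in place of 4-fluorophenyl on an aromatic nitrogen. Among the measured compounds shown here, no measured step touches this same position with a comparable change; the only step in hand, from compound 1 to compound 2, altered a substituent on the same aromatic ring and stayed within the scatter. On that basis no step beyond the scatter is expected in this assay from compound 2 to compound 3, and the range is widened for the larger change.

Compound 3 is estimated at 25000 nM, between 9000 nM and 70000 nM, an expected step of a 1.0-fold lower number from compound 2 to compound 3 (0.02 log units; within the scatter).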

Compound 3, half-maximal inhibitory concentration: 18900 nM
For compound 3 the middle estimate is 1.3-fold (0.12 log units) above the measured one; the range from low to high includes it.
By their numbers in this assay, from the lowest: compounds 3, 2 and 1 (each within the scatter of the next).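

In this assay, replacing the whole aryl group on the aromatic nitrogen, rather than one substituent on it, gives a 1.4-fold lower number from compound 2 to compound 3 (0.14 log units; within the scatter); the corresponding replacement of 3-chloro-4-fluorophenyl gives a 1.4-fold lower number from compound 1 to compound 3 (0.16 log units; within the scatter). The position therefore accepts 3-(trifluoromethyl)phenyl, a larger group with its substituent placed differently, without a separation from either earlier compound in this assay. Nothing available offers an explanation for how closely these values lie together.

Going by these compounds, whether an amine or a carboxylic acid on this phenyl ring, or a longer alkyl chain in place of the ring, would give a step beyond the scatter remains open. Also open, on these data alone, is how much the values depend on the shared core, which is the same in all three compounds.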